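This account rests on a few compounds, and the source may have more. Where it says the series, first, only, none or still open, it means among the compounds named here.

Three compounds share a core in which a phenyl ring is joined to a fused two-ring system. Compound 1 `Cc1ccccc1-c1ccc2[nH]ncc2c1` carries a methyl group on the phenyl ring, and in an assay on CHO-TREX cells for antagonist activity at transient receptor potential cation channel subfamily A member 1 (Homo sapiens), read by FLIPR and calcium flux, with a stated time of 10 min (on this read-out higher numbers stand for weaker inhibition and lower numbers for stronger inhibition), compound 1 gives 7810 nM. Compound 2 `N#Cc1ccccc1-c1ccc2[nH]ncc2c1` carries a nitrile in that place, and in this assay compound 2 gives 1290 nM; the change amounts to a 6.1-fold lower number from compound 1 to compound 2 (0.78 log units; beyond the scatter). Compound 3 `Fc1cc2[nH]ncc2cc1-c1ccccc1C(F)(F)F` has a trifluoromethyl group on the phenyl ring and a fluoro on the fused system; in this assay compound 3 gives 48 nM, the lowest of the three numbers, standing clear of compound 2 and compound 1 by margins beyond the usual scatter.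

Compound 4 `FC(F)(F)c1ccccc1-c1cc2cn[nH]c2cc1C1CC1` differs from compound 3 in one place: cyclopropyl in place of fluoro on an aromatic carbon. Within the data shown here, no measured step bears on this change. Among the measured compounds shown here, the only measured step, from compound 1 to compound 2, concerns the phenyl ring and a different pair of groups, so it gives no guide to direction or size here. With nothing to build on, a step of a 1.3-fold higher number from compound 3 to compound 4 (0.10 log units; within the scatter) in this assay is expected, meaning no clear movement beyond the scatter, with a wide band of uncertainty around it. Compound 4 is estimated at 60 nM, within a range from 15 nM to 250 nM.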

Compound 4, half-maximal inhibitory concentration: 61 nM
The estimate for compound 4 lay 1.0-fold (0.01 log units) below the measured number; low and high end bracket the measured number.
By their numbers in this assay, from the lowest: compounds 3 and 4 (each within the scatter of the next); then compound 2; then compound 1.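

In this assay, putting cyclopropyl in place of fluoro gives a 1.3-fold higher number from compound 3 to compound 4 (0.10 log units; within the scatter), so the two compounds cannot be told apart. The earlier step concerned the phenyl ring, whereas this one shows something about the aromatic carbon of the fused system: a single fluorine and a three-carbon group with its own ring read alike there, with the trifluoromethyl group on the phenyl ring kept in both compounds. No measurement here explains why these two groups read alike.

Fluoro and cyclopropyl both have no hydrogen-bond donors or acceptors and no net charge, which leaves open how an amine, a carboxylic acid or a longer carbon chain would read at this place. Also open, going by these compounds, is how a plain hydrogen would compare at this position with the trifluoromethyl group kept in place, as compound 2 and compound 3 differ in more than one place and their gap cannot be assigned to either change.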